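This account rests on a few compounds, and the source may have more. Where it says the series, first, only, none or still open, it means among the compounds named here.

Working notes on the series. Of the compounds shown here, three of the shared core have been measured in an assay on mitochondria for inhibition of 1,25-dihydroxyvitamin D(3) 24-hydroxylase, mitochondrial (Rattus norvegicus); a lower number here means a stronger inhibitor, a higher number a weaker inhibitor. Compound 1 `COc1ccc2c(c1)CCC(Cc1ccc(O)cc1)C2=O` gives 3500 nM in this assay. Compound 3 `CN(C)c1ccc(CC2CCc3cc(O)ccc3C2=O)cc1` gives 18000 nM in this assay, which is the higher of the two numbers in the set; the gap from compound 1 to compound 3 lies beyond the scatter, with compound 1 the lower of the two. Compound 2 `CN(C)c1ccc(/C=C2\CCc3cc(O)ccc3C2=O)cc1` gives > 100000 nM in this assay, and this is a limit of the assay rather than a number (the limit of > 100000 nM in this assay, at which 1 of the 3 values shown sits).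

Compound 4 `O=C1c2ccc(O)cc2CCC1Cc1ccc(-c2ccccc2)cc1` has not yet been measured in this assay. It differs from compound 3 in one place: phenyl in place of dimethylamino on an aromatic carbon. Among the compounds with values here, no measured pair in the set carries this change, so its size can only be estimated. The two measured numbers, compound 1 at 3500 nM and compound 3 at 18000 nM, span a modest range, and the expected step from a 1.8-fold lower number from compound 3 to compound 4 (0.26 log units; within the scatter) is a small move toward a lower number, within or just beyond the scatter. The estimate for compound 4 in this assay is 10000 nM, with a range from 3000 nM to 40000 nM.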

Compound 4, half-maximal inhibitory concentration: > 20000 nM
Compound 4 was reported as a limit; the forecaster's own chance of this, stated with the estimate: 10%; at least 2.0-fold (0.30 log units) between middle value and limit.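

Compound 4 is reported as a limit and not a number in this assay: the limit of > 20000 nM in this assay, at which 1 of the 4 values shown sits. Within the data shown here, this gives the first reading of a change at this aromatic carbon, para to a large group, and the step from dimethylamino to phenyl reads an at least 1.1-fold higher number from compound 3 to compound 4 (0.04 log units; that floor lies within the scatter), a floor with no upper bound, so its true size cannot be read. The result therefore shows no gain from exchanging dimethylamino, with its nitrogen and one hydrogen-bond acceptor, for phenyl, with its six-membered aromatic ring of carbon only, although the floor does not establish a loss beyond the scatter.

From the compounds shown here alone, it remains open how far the number for compound 4 lies past its limit, and so whether this change is neutral or costly in this assay. The compounds shown also leave open how a primary amine or a carboxylic acid on this aromatic carbon would read, which would help separate the part played by the nitrogen from that played by the added ring.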